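The source may report more compounds than this note shows. Statements on the series, on what has been measured and on what is new or still open speak of the compounds shown alone.

Working notes on the series. In a functional assay on HeLa cells (Homo sapiens) for antiproliferative activity, read by MTT assay, with a stated time of 48 h (a lower number here means a stronger inhibitor of growth, a higher number a weaker inhibitor of growth), compound 1 `CCOC(=O)c1sc2ccc(NCc3c[nH]cn3)cc2c1NC(=O)c1ccc(OC)cc1` gives 12900 nM, the highest of the three numbers in hand, though all three sit within the scatter of one another. Compound 2 `CCOC(=O)c1sc2ccc(NCc3c[nH]cn3)cc2c1NC(=O)c1cc(OC)c(OC)c(OC)c1` gives 6790 nM and compound 3 `CCOC(=O)c1sc2ccc(NCc3c[nH]cn3)cc2c1NC(=O)c1ccc(F)c(Cl)c1` gives 10700 nM in this assay; the steps of a 1.9-fold lower number from compound 1 to compound 2 (0.28 log units; within the scatter) and a 1.2-fold lower number from compound 1 to compound 3 (0.08 log units; within the scatter) are both small, as is a 1.6-fold higher number from compound 2 to compound 3 (0.20 log units; within the scatter).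

Compound 4 `CCOC(=O)c1sc2ccc(NCc3nc[nH]c3C)cc2c1NC(=O)c1ccc(OC)cc1` differs from compound 1 by methyl in place of hydrogen on an aromatic carbon. Among the compounds with values here, no measured step touches this part of the shared core; all three vary the aryl on the carbonyl carbon, and none moved this assay beyond the scatter. No step beyond the scatter is therefore expected in either direction.

Compound 4 is expected to give 12000 nM in this assay, within 5000 nM to 30000 nM, an expected step of a 1.1-fold lower number from compound 1 to compound 4 (0.03 log units; within the scatter).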

Compound 4, concentration for 50% growth inhibition: 8220 nM
Estimate against measurement, compound 4: 1.5-fold (0.16 log units) above, within the range that was stated.
By their numbers in this assay, from the lowest: compounds 2, 4, 3 and 1 (each within the scatter of the next).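

In this assay, methyl in place of hydrogen on an aromatic carbon of the imidazole gives a 1.6-fold lower number from compound 1 to compound 4 (0.20 log units; within the scatter). This is the only step shown outside the aryl on the carbonyl carbon, and like the aryl steps it does not move the number beyond the scatter. Nothing at hand bears on this result.

Still open, from the compounds shown here alone, is whether a longer chain, an amine or a carboxylic acid on this ring carbon would give a step beyond the scatter. Also open, going by these compounds, is whether methyl here gives a similar step with the 3,4,5-trimethoxyphenyl of compound 2.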